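Cytotoxicity on HEL cells: from compound 2 to compound 3

The source may report more compounds than this note shows. Statements on the series, on what has been measured and on what is new or still open speak of the compounds shown alone.

Of the compounds shown here, two of a shared core have been tested in an ADME assay on HEL cells (Homo sapiens) for cytotoxicity; a lower number here means that less compound is tolerated, a higher number that more compound is tolerated. Compound 1 `C/C(=N\NC(=O)COc1cccc2ccccc12)c1ccccc1Br` gives 20 ug/mL in this assay, and compound 2 `C/C(=N\NC(=O)COc1cccc2ccccc12)c1ccc([N+](=O)[O-])cc1` gives 100 ug/mL. Among the compounds with values here, compound 2 therefore stands at the highest of the two numbers measured so far, with compound 1 the only neighbour, and the step of a 5.0-fold higher number from compound 1 to compound 2 (0.70 log units; beyond the scatter) is the single measured step.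

Compound 3 `C/C(=N\NC(=O)COc1cccc2ccccc12)c1ccccc1O` is not yet measured. It differs from compound 2 in one place: 2-hydroxyphenyl in place of 4-nitrophenyl on a carbon with a double bond to nitrogen. Within the data shown here, no measured step covers this change directly, since the one step known, a 5.0-fold higher number from compound 1 to compound 2 (0.70 log units; beyond the scatter), compares two other groups at the same carbon. That step shows that exchanging the group on this carbon can move the number by a modest amount. As compound 3 carries a group different from both compound 1 and compound 2, the direction is uncertain, and a modest step down from the highest number is taken as the more likely outcome. The expected step is a 2.0-fold lower number from compound 2 to compound 3 (0.30 log units; within the scatter). For compound 3 the estimate in this assay is 50 ug/mL, within a range from 20 ug/mL to 125 ug/mL.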

Compound 3, minimum cytotoxic concentration: 20 ug/mL
The estimate for compound 3 lay 2.5-fold (0.40 log units) above the measured number; measured number inside the range.
By their numbers in this assay, from the lowest: compounds 1 and 3 (each within the scatter of the next); then compound 2.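

In this assay the group on the carbon with a double bond to nitrogen now has a second step beyond the scatter: a 5.0-fold lower number from compound 2 to compound 3 (0.70 log units; beyond the scatter) shows that the number falls when 4-nitrophenyl leaves, and it does so with a group other than 2-bromophenyl entering. The exchange of hydroxy for bromo on an aromatic carbon gives no change at the digits printed from compound 1 to compound 3 (within the scatter) and so does not separate 2-hydroxyphenyl from 2-bromophenyl in this assay, even though only the first carries a hydrogen-bond donor, leaving compound 2 alone at the higher number. Nothing measured here accounts for this separation.

Compound 2 differs from both compound 1 and compound 3 in the group and in where it sits on the phenyl ring, so these compounds cannot tell whether the higher number follows the nitro group or its place. A nitro group placed as the bromo and hydroxy groups are, a bromo or hydroxy group placed as the nitro group is, or an amine or a carboxylic acid on the same ring would bear on that question.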